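The source may report more compounds than this note shows. Statements on the series, on what has been measured and on what is new or still open speak of the compounds shown alone.

Compound 1 `Cc1ccc(-c2nn(-c3ccc(F)cc3F)cc2CNCCN2CCN(C)CC2)cc1` — in an ADME assay on Huh-7 cells (Homo sapiens) for cytotoxicity (on this read-out higher numbers stand for lower toxicity in this test and lower numbers for higher toxicity in this test), compound 1 gives > 20000 nM, a limit of the assay rather than a number.
Compound 2 `CN1CCN(CCNCc2cn(-c3ccc(F)cc3F)nc2C2CCCCC2)CC1` — in this assay compound 2 gives > 20000 nM, again a limit of the assay rather than a number.
Compound 3 `CCCN1CCC(CNCc2cn(-c3ccc(C(F)(F)F)cc3)nc2-c2ccc(C(F)(F)F)cc2)CC1` — in this assay compound 3 gives 1200 nM.

Compound 2 therefore stands at the limit of > 20000 nM in this assay, at which 2 of the 3 values shown sit, and its value is known only as a limit. Within the data shown here, the one measured step that touches it, a step that the two limits leave unreadable from compound 1 to compound 2, is unreadable because both of its ends are limits, so its size cannot be told.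

The step from compound 2 to compound 4 `CN1CCN(CCNCc2cn(-c3ccc(F)cc3F)nc2C(C)(C)C)CC1` is tert-butyl in place of cyclohexyl on an aromatic carbon. Among the measured compounds shown here, no measured step covers this change, and the only step that shares compound 2 gives no size. For the measured compounds named here, compound 3, the single compound with a number, differs from compound 2 at several places at once, so its value cannot be read as a step either. With nothing pointing to a change beyond the usual scatter, compound 4 is expected to stay where compound 2 stands, with a step that the limit leaves unreadable from compound 2 to compound 4 that is not expected to leave the scatter. Compound 4 is thus estimated at 30000 nM, with a range from 15000 nM to 60000 nM, and it is likely that the assay will again report only a limit.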

Compound 4, half-maximal cytotoxic concentration: > 20000 nM
Compound 4 ended at the assay's limit; the forecaster's own chance of this, stated with the estimate: 70%; the middle value is on the limit's open side.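

In this assay compound 4 sits at a limit of the assay, as do compound 1 and compound 2, so no step among these three compounds can be read: the limit of > 20000 nM in this assay, at which 3 of the 4 values shown sit.
The compounds shown leave open whether 4-methylphenyl, cyclohexyl and tert-butyl differ at all on this read-out.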